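The source may report more compounds than this note shows. Statements on the series, on what has been measured and on what is new or still open speak of the compounds shown alone.

Compound 1, `COC(=O)C[C@H](NC(=O)OC(C)(C)C)C(=O)N(Cc1ccc(F)cc1)C1(C(=O)NCc2ccccc2)CCN(C)CC1`, was examined in an ADME assay on MDCK cells (Canis lupus familiaris) for cytotoxicity, read by microscopy, with a stated time of 72 h (a higher number here means that more compound is tolerated, a lower number that less compound is tolerated), where compound 1 gives 17000 nM. Two other compounds sharing the same core were examined alongside it: compound 2, `COC(=O)C[C@H](N)C(=O)N(Cc1ccc(F)cc1)C1(C(=O)NCc2ccccc2)CCN(Cc2ccccc2)CC1`, gives 60000 nM, and compound 3, `CC(C)(C)OC(=O)N[C@@H](CC(=O)O)C(=O)N(Cc1ccc(F)cc1)C1(C(=O)NCc2ccccc2)CCNCC1`, gives 79000 nM. Among these three, compound 1 stands lowest, with compound 2 nearest and compound 3 furthest, both gaps lying beyond the usual scatter. Compound 4, `COC(=O)C[C@H](NC(=O)OC(C)(C)C)C(=O)N(Cc1ccc(F)cc1)C1(C(=O)NCc2ccccc2)CCN(Cc2cc(F)cc(F)c2)CC1`, differs from compound 1 in a single place: 3,5-difluorophenyl in place of hydrogen on a saturated chain carbon bound to an amine nitrogen in a ring. Within the data shown here, no measured pair reproduces exactly this change, so the account can only say what the values themselves show. The step from compound 1 to compound 4 is expected to be small, a 1.2-fold higher number from compound 1 to compound 4 (0.07 log units; within the scatter), not clearly beyond the scatter in either direction. Compound 4 is therefore estimated at 20000 nM, within a range from 7000 nM to 60000 nM.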

Compound 4, minimum cytotoxic concentration: 100000 nM
Compound 4: the middle estimate sits 5.0-fold (0.70 log units) below what was measured; the whole stated range lies below it.
By their numbers in this assay, from the lowest: compound 1; then compounds 2, 3 and 4 (each within the scatter of the next).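

On the saturated chain carbon bound to an amine nitrogen in a ring, replacing methyl with 3,5-difluorobenzyl gives, in this assay, a 5.9-fold higher number from compound 1 to compound 4 (0.77 log units; beyond the scatter). This position therefore responds to the change, and adding the 3,5-difluorophenyl ring moves the number beyond the scatter. No available evidence accounts for the size of this step. Among these compounds, with only this one step, the ring and its two fluorines cannot be told apart. Going by these compounds, whether a plain benzyl, a longer alkyl chain or a carboxylic acid at this position would give a similar step remains open.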